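From Isopropyl to Phenethyl in a Cytotoxicity Test

A few compounds are considered here, and "the series" means these few. Any claim that something is new, unique, unknown or untested is made for them only; others in the source may bear on it.

In an ADME assay on HL-60 cells (Homo sapiens) for cytotoxicity, read by MTT assay, with a stated time of 24 h (a higher number here means a weaker inhibitor, a lower number a stronger inhibitor), compound 1 `CC(C)CN(C)Cc1ccc(C2=CCCN(C)C2)cc1` gives > 50000 nM as a limit of the assay and not a number. Compound 2 `CC(C)CN(C)Cc1ccc(C2CCCN(C)C2)cc1` also gives > 50000 nM as a limit and not a number. Both compounds therefore sit at the limit of > 50000 nM in this assay, at which 2 of the 2 values shown sit, and neither offers an exact figure to start from.

Compound 3 `CN(CCCc1ccccc1)Cc1ccc(C2CCCN(C)C2)cc1` differs from compound 2 in one place, with phenethyl in place of isopropyl on a saturated chain carbon bound to an amine nitrogen. For the measured compounds named here, no pair of measured compounds shows what such a swap does, so the expectation here rests on the structural change alone and is a cautious one. A modest shift toward a stronger inhibitor is expected in this assay for compound 3, and it may well turn out to be no more than the usual scatter, or to end at the same limit. The expected size of the move is small (an at least 2.0-fold lower number from compound 2 to compound 3 (0.30 log units; that floor lies within the scatter)). For compound 3 the estimated value is 25000 nM with a wide expected range (8000 nM to 70000 nM).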

Compound 3, half-maximal inhibitory concentration: > 50000 nM
Compound 3 gave a limit, no number; the forecaster's own chance of this, stated with the estimate: 45%; middle value at least 2.0-fold (0.30 log units) away from the limit.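

In this assay compound 3 gives > 50000 nM as a limit of the assay and not a number. No size can therefore be read for the step from compound 2 to compound 3, because both compounds end at the same limit: the limit of > 50000 nM in this assay, at which 3 of the 3 values shown sit. The compounds shown leave open whether phenethyl in place of isopropyl changes the true value at all.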